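A few compounds are considered here, and "the series" means these few. Any claim that something is new, unique, unknown or untested is made for them only; others in the source may bear on it.

Measured compounds and their oral bioavailability values:

compound 1, `CC(=O)Nc1ccc(-c2nn(C)/c(=N/C3CCCC(O)C3)s2)cc1`: 76%
compound 2, `Cn1nc(-c2ccc(C(=O)NC(C)(C)CO)cc2)s/c1=N\C1CCCC(O)C1`: 63%
compound 3, `Cn1nc(-c2ccc(C(N)=O)cc2)s/c1=N\C1CCCCC1O`: 24.7%

In an in vivo ADME assay on the whole organism (Eutheria) for pharmacokinetics (on this read-out lower numbers stand for lower oral bioavailability and higher numbers for higher oral bioavailability), compound 3 stands lowest of the three measured numbers, and both compound 2 and compound 1 lie well above it, beyond the scatter in each case. Compound 4, `Cn1nc(-c2ccc(C(N)=O)cc2)s/c1=N\C1CCC(O)CC1`, differs from compound 3 in one place: 4-hydroxycyclohexyl in place of 2-hydroxycyclohexyl on a double-bonded nitrogen. Among the measured compounds shown here, the only measured step, a number 13 percentage points lower from compound 1 to compound 2 (beyond the scatter), concerns a change on the aromatic carbon and leaves the ring on the double-bonded nitrogen untouched, so no measured step bears directly on the change from compound 3 to compound 4. The data therefore give no footing for a step beyond the scatter in either direction; the step expected, a number 7.3 percentage points higher from compound 3 to compound 4 (within the scatter), is accordingly small and uncertain. Compound 4 is estimated at 32%, with a range from 15% to 55% that reflects the lack of a comparable measured step.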

Compound 4, oral bioavailability: 7%
The estimate for compound 4 lay 25 percentage points above the measured number; measured number outside the range, below it.
By their numbers in this assay, from the lowest: compound 4; then compound 3; then compound 2; then compound 1.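

In this assay, 4-hydroxycyclohexyl in place of 2-hydroxycyclohexyl on a double-bonded nitrogen gives a number 17.7 percentage points lower from compound 3 to compound 4 (beyond the scatter) and makes compound 4 the lowest of the four compounds. The two groups have the same atoms and the same counts of donors and acceptors, so a change in how those atoms are joined is enough here to move the number beyond the scatter, which the earlier step on an aromatic carbon could not show. No measurement shown explains this drop.

As far as these compounds go, it remains open whether the same step would appear with acetamido or (1-(hydroxymethyl)-1-methylethyl)carbamoyl on the aromatic carbon. Also open, from the compounds shown here alone, is how an amine or a carboxylic acid in place of the hydroxyl on the six-membered ring would read out.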